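Compound 3 to compound 4: a second methyl group

This account rests on a few compounds, and the source may have more. Where it says the series, first, only, none or still open, it means among the compounds named here.

The shared core is that of compound 1 `O=C(/C=C/c1ccc(N2CCCCC2)cc1)c1cccs1`, the unmethylated parent. In an ADME assay on PBMC cells (Homo sapiens) for cytotoxicity, with a stated time of 5 days (a higher number here means a weaker inhibitor, a lower number a stronger inhibitor), compound 1 gives > 100000 nM, which is a limit of the assay and not a number (the limit of > 100000 nM in this assay, at which 1 of the 3 values shown sits). Compound 2 `Cc1ccsc1C(=O)/C=C/c1ccc(N2CCCCC2)cc1` gives 26400 nM in this assay. Compound 3 `Cc1csc(C(=O)/C=C/c2ccc(N3CCCCC3)cc2)c1` gives 68800 nM in this assay, the highest of the two numbers shown, with compound 2 nearest at a 2.6-fold higher number from compound 2 to compound 3 (0.42 log units; beyond the scatter). Adding one methyl to the parent gave an at least 3.7-fold lower number from compound 1 to compound 2 (0.57 log units; beyond the scatter) and, less clearly, an at least 1.4-fold lower number from compound 1 to compound 3 (0.16 log units; that floor lies within the scatter). Compound 4 `Cc1cc(C(=O)/C=C/c2ccc(N3CCCCC3)cc2)c(C)s1` differs from compound 3 by 2,5-dimethylthiophen-3-yl in place of 4-methylthiophen-2-yl on a carbonyl carbon. The two methyl steps bear on this change, since compound 4 carries a second methyl on the same five-membered aromatic ring; one of those steps was beyond the scatter, the other had a floor within it, and no step with two methyls is shown. A modest lowering of the number is therefore expected rather than a large one, and given an at least 3.7-fold lower number from compound 1 to compound 2 (0.57 log units; beyond the scatter) and an at least 1.4-fold lower number from compound 1 to compound 3 (0.16 log units; that floor lies within the scatter) the expected step is a 2.0-fold lower number from compound 3 to compound 4 (0.29 log units; within the scatter). Compound 4 is thus expected to give 35000 nM in this assay, with a range from 12000 nM to 100000 nM.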

Compound 4, half-maximal inhibitory concentration: 38200 nM
The estimate for compound 4 lay 1.1-fold (0.04 log units) below the measured number; the range from low to high includes it.
By their numbers in this assay, from the lowest: compounds 2, 4 and 3 (each within the scatter of the next, the first and the last beyond it). At a limit, above all of these: compound 1.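

In this assay, the change to 2,5-dimethylthiophen-3-yl on the carbonyl carbon gives a 1.8-fold lower number from compound 3 to compound 4 (0.26 log units; within the scatter) and a 1.4-fold higher number from compound 2 to compound 4 (0.16 log units; within the scatter), so a second methyl together with the shift from a thiophen-2-yl to a thiophen-3-yl group does not set compound 4 apart from either singly methylated compound. Measured against the unmethylated parent, the same group gives an at least 2.6-fold lower number from compound 1 to compound 4 (0.41 log units; beyond the scatter), which places compound 4 with the two methylated compounds, and this step is a floor and not an exact size. Compound 1 gives a limit of the assay and not a number: the limit of > 100000 nM in this assay, at which 1 of the 4 values shown sits.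

The change from compound 3 to compound 4 alters the methyl count and the ring attachment at once, and the compounds shown do not separate these two changes; a single-methyl group such as 5-methylthiophen-3-yl would bear directly on that question. On these data alone, it also remains open whether a different substituent on the same five-membered aromatic ring, such as an ethyl group, a primary amine or a carboxylic acid, would move the number in this assay beyond the scatter of the methylated compounds.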